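The source may hold more compounds than are shown below. What is called first, only, known or untested is meant among the compounds shown, and "the series" means these compounds.

- compound 1 `COc1ccc(CN(C(=O)CSc2nc3ccccc3s2)c2cc(OC)c(OC)c(OC)c2)cc1C` gives 6360 nM 
- compound 2 `COc1cc(CN(C(=O)CSc2nc3ccccc3s2)c2cc(OC)c(OC)c(OC)c2)cc(OC)c1OC` gives 45700 nM 

Both numbers come from a functional assay on MGC-803 cells (Homo sapiens) for antiproliferative activity, read by MTT assay, with a stated time of 48 h (a lower number here means a stronger inhibitor, a higher number a weaker inhibitor), and compound 2 has the higher one, which makes it the weaker inhibitor of this pair. Compound 3 `COc1cc(N(Cc2ccccc2)C(=O)CSc2nc3ccccc3s2)cc(OC)c1OC` has phenyl in place of 3,4,5-trimethoxyphenyl on a saturated chain carbon bound to an amide-type nitrogen and is otherwise the same as compound 2. Going by the values given here, only one measured step bears on this change. It is modest, beyond the scatter, and it introduced the same 3,4,5-trimethoxyphenyl group: a 7.2-fold higher number from compound 1 to compound 2 (0.86 log units; beyond the scatter) in this assay on going to that group. Removing the group is therefore expected to lower the number by a similar amount, though an unsubstituted phenyl has not been measured here. The expected change is a 4.6-fold lower number from compound 2 to compound 3 (0.66 log units; beyond the scatter) by this estimate. The estimated value for compound 3 is 10000 nM with an expected range of 3000 nM to 35000 nM in this assay.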

Compound 3, half-maximal inhibitory concentration: 44300 nM
Estimate against measurement, compound 3: 4.4-fold (0.65 log units) below, and the stated range ends below it.
By their numbers in this assay, from the lowest: compound 1; then compounds 3 and 2 (each within the scatter of the next).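

In this assay, stripping the methoxy groups from this ring leaves the number unchanged within the scatter, with a 1.0-fold lower number from compound 2 to compound 3 (0.01 log units; within the scatter) on going to phenyl. The 3,4,5-trimethoxyphenyl group therefore offers no gain or loss over a bare phenyl, and the stronger result belongs to the 4-methoxy-3-methylphenyl group of compound 1, with a 7.0-fold higher number from compound 1 to compound 3 (0.84 log units; beyond the scatter) once that group is replaced by phenyl. No evidence on hand explains this. Still open, as far as these compounds go, is whether 4-methoxyphenyl or 3-methylphenyl alone would match compound 1, and how a ring bearing an amine or a carboxylic acid would behave.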